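The source may hold more compounds than are shown below. What is called first, only, known or untested is meant among the compounds shown, and "the series" means these compounds.

Two close relatives have so far been tested in a functional assay on MCF7 cells (Homo sapiens) for cytotoxicity, read by MTT assay, with a stated time of 24 h; on this read-out higher numbers stand for weaker inhibition and lower numbers for stronger inhibition. Compound 1 `C/C(=N\NC(=O)/C(C#N)=C/c1cccc([N+](=O)[O-])c1)c1c(O)c2ccc(O)cc2oc1=O` gives 16400 nM, and compound 2 `C/C(=N\NC(=O)/C(C#N)=C/c1ccccc1[N+](=O)[O-])c1c(O)c2ccc(O)cc2oc1=O` gives 9180 nM. Within the data shown here, these two numbers lie within the usual scatter of repeated measurements, so compound 2 cannot be told apart from its only measured neighbour.

The next molecule, compound 3 `C/C(=N\NC(=O)/C(C#N)=C/c1cccc(Br)c1)c1c(O)c2ccc(O)cc2oc1=O`, keeps the shared core and differs from compound 2 in one place: 3-bromophenyl in place of 2-nitrophenyl on a double-bonded chain carbon bound to a double-bonded chain carbon. Among the measured compounds shown here, only one measured step bears on this change. Exchanging 3-nitrophenyl for 2-nitrophenyl gave a 1.8-fold lower number from compound 1 to compound 2 (0.25 log units; within the scatter). For the measured compounds named here, that step shows only that the two nitrophenyl compounds sit close together, and no measured compound here carries bromine, so the data offer no direct guide to the new group and no firm direction. Going by the values given here, with that small step as the only evidence, no change beyond the scatter is expected, though the range must stay wide. The expected step is a 1.3-fold higher number from compound 2 to compound 3 (0.12 log units; within the scatter). For compound 3 the estimated value is 12000 nM, with an expected range of 5000 nM to 30000 nM.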

Compound 3, half-maximal inhibitory concentration: 19600 nM
Compound 3: the middle estimate sits 1.6-fold (0.21 log units) below what was measured; the measured number falls inside the stated range.
By their numbers in this assay, from the lowest: compounds 2, 1 and 3 (each within the scatter of the next, the first and the last beyond it).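

Among these compounds, on a double-bonded chain carbon bound to a double-bonded chain carbon, 3-bromophenyl in place of 2-nitrophenyl gives a 2.1-fold higher number from compound 2 to compound 3 (0.33 log units; beyond the scatter) in this assay, the first step in this small set to pass beyond the scatter, though only modestly. The comparison with the other nitro compound reads differently: bromo in place of nitro on an aromatic carbon gives a 1.2-fold higher number from compound 1 to compound 3 (0.08 log units; within the scatter), so exchanging these two groups on an aromatic carbon produces no readable change, and the one clear gap lies only between 2-nitrophenyl and 3-bromophenyl, two names that differ both in the group and in its number on the ring. No supporting measurement is available to explain why these numbers differ.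

The compounds shown leave open whether the gap follows the ring number or the group itself, a question that 2-bromophenyl, carrying bromine with the number of the nitro group in compound 2, could help to settle. They also leave open how an unsubstituted phenyl ring, or a phenyl ring bearing an amine or a carboxylic acid, would read at this place.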